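The source may report more compounds than this note shows. Statements on the series, on what has been measured and on what is new or still open speak of the compounds shown alone.

In a functional assay on MCF7 cells (Breast, Homo sapiens) (a lower number here means that less compound is needed, a higher number that more compound is needed for the effect), compound 1 (`COc1cc2nc(-c3ccccc3F)nc(O)c2cc1OC`) gives 13.1 ug/mL and compound 3 (`COc1cc2nc(-c3ccc(F)cc3)nc(O)c2cc1OC`) gives 19.8 ug/mL. The measured step between them is a 1.5-fold higher number from compound 1 to compound 3 (0.18 log units; within the scatter). Compound 2 (`COc1cc2nc(-c3cccc(F)c3)nc(O)c2cc1OC`) is recorded as "not active" (no number reported), so it stands without a number, and its distance from the other two cannot be stated. Compound 4 (`COc1cccc(-c2nc(O)c3cc(OC)c(OC)cc3n2)c1`) differs from compound 2 by methoxy in place of fluoro on an aromatic carbon, meta to a large group. Among the compounds with values here, no measured step makes this exchange. Within the data shown here, the one step available, a 1.5-fold higher number from compound 1 to compound 3 (0.18 log units; within the scatter), swaps 2-fluorophenyl for 4-fluorophenyl and only loosely bears on it. With no number at the starting point, neither a size nor a direction can be expected for the change itself. The expectation therefore leans on the numbers of the two measured neighbours, compound 1 at 13.1 ug/mL and compound 3 at 19.8 ug/mL, and it stays wide, since a result without a number is also possible. Compound 4 is expected at about 22 ug/mL, with an estimated range from 8 ug/mL to 60 ug/mL.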

Compound 4, concentration for half-maximal effect: 14.5 ug/mL
Compound 4: the middle estimate sits 1.5-fold (0.18 log units) above what was measured, and the stated range covers the measured number.
By their numbers in this assay, from the lowest: compounds 1, 4 and 3 (each within the scatter of the next).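

Within the data shown here, compound 2 has no number in this assay, so no step from compound 2 to compound 4 can be read. The compounds shown leave open what methoxy in place of fluoro does to the number, and no evidence at hand bears on the result for compound 4.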